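The source may hold more compounds than are shown below. What is called first, only, known or untested is meant among the compounds shown, and "the series" means these compounds.

Measured in a functional assay on HT-29 cells (Homo sapiens); a higher number here means a weaker inhibitor of growth, a lower number a stronger inhibitor of growth:
Compound 1 `O=S(=O)(/C=C/c1ccccc1)Cc1ccc(Nc2ncnc3ccccc23)cc1`: > 100000 nM, a limit and not a number
Compound 2 `O=S(=O)(/C=C/c1ccc(Cl)c(Cl)c1)Cc1ccc(Nc2ncnc3ccccc23)cc1`: 11000 nM
Compound 3 `O=S(=O)(/C=C/c1ccc(C(F)(F)F)cc1F)Cc1ccc(Nc2ncnc3ccccc23)cc1`: 100000 nM

Compound 3 gives 100000 nM, the higher of the two actual numbers, and the gap to the other is a 9.1-fold higher number from compound 2 to compound 3 (0.96 log units; beyond the scatter). Compound 4 `O=S(=O)(/C=C/c1ccc(C(F)(F)F)cc1F)Cc1ccc(Nc2ncnc3cc(Cl)ccc23)cc1` carries one change, chloro in place of hydrogen on an aromatic carbon: quinazolin-4-yl becomes 7-chloroquinazolin-4-yl. Going by the values given here, no measured step touches this place. Among the compounds with values here, the nearest guides are changes on the phenyl end, an at least 9.0-fold lower number from compound 1 to compound 2 (0.95 log units; beyond the scatter) and a 9.1-fold higher number from compound 2 to compound 3 (0.96 log units; beyond the scatter), which show only that one change can move this assay by a modest amount. A modest fall is therefore expected, held with little confidence. The expected step is a 2.5-fold lower number from compound 3 to compound 4 (0.40 log units; beyond the scatter). For compound 4 the estimate is 40000 nM, with an expected range of 8000 nM to 150000 nM.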

Compound 4, concentration for 50% growth inhibition: > 100000 nM
Compound 4: no number, only a limit; the forecaster's own chance of this, stated with the estimate: 25%; middle value at least 2.5-fold (0.39 log units) from the limit.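

In this assay compound 4 gives > 100000 nM, which is a limit and not a number. The only change shown on this side of the molecule, chloro in place of hydrogen on the aromatic carbon, brought no fall, and any rise cannot be sized: a number no lower from compound 3 to compound 4 (the limit leaves the size open). The reading stands at a limit shared within this set: the limit of > 100000 nM in this assay, at which 2 of the 4 values shown sit.

From the compounds shown here alone, it remains open whether chloro at this carbon would act differently alongside the 3,4-dichlorophenyl group of compound 2. Going by these compounds, it also remains open whether a methoxy group or an amine there would lower the number.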